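This account rests on a few compounds, and the source may have more. Where it says the series, first, only, none or still open, it means among the compounds named here.

Measured compounds:
compound 1 `CCOC(=O)C1=Cc2ccccc2OC1(OCc1cn(CC(=O)Nc2cccc(Cl)c2)nn1)C(F)(F)F` — 10100 nM
compound 2 `CCOC(=O)C1=Cc2ccccc2OC1(OCc1cn(CC(=O)NC2CCCCC2)nn1)C(F)(F)F` — 10200 nM
compound 3 `Cc1ccc(-c2cc(COC3(C(F)(F)F)Oc4ccccc4C=C3C(=O)O)on2)cc1` — 41400 nM

In a functional assay on DU-145 cells (Homo sapiens) for inhibition, read by MTT assay, with a stated time of 24 h (on this read-out lower numbers stand for stronger inhibition and higher numbers for weaker inhibition), compound 2 gives 10200 nM, the second highest of the three numbers. Compound 1 gives 10100 nM, which lies within the scatter of compound 2, while compound 3 gives 41400 nM, well beyond it. Compound 4 `CCOC(=O)C1=Cc2ccccc2OC1(OCc1cn(CC(=O)Nc2ccc(OC)cc2)nn1)C(F)(F)F` differs from compound 2 by 4-methoxyphenyl in place of cyclohexyl on an amide-type nitrogen. Within the data shown here, one measured step touches the same place: a 1.0-fold higher number from compound 1 to compound 2 (0.00 log units; within the scatter), where exchanging the group on the amide-type nitrogen left the number essentially unchanged. Because of a 1.0-fold higher number from compound 1 to compound 2 (0.00 log units; within the scatter), no step beyond the scatter is expected here either, so the expected step is a 1.0-fold lower number from compound 2 to compound 4 (0.01 log units; within the scatter). Compound 4 is therefore estimated at 10000 nM, with a range from 5000 nM to 20000 nM.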

Compound 4, half-maximal inhibitory concentration: 32700 nM
Beside the measured number, compound 4's estimate is 3.3-fold (0.51 log units) below it, outside the stated range (above it).
By their numbers in this assay, from the lowest: compounds 1 and 2 (each within the scatter of the next); then compounds 4 and 3 (each within the scatter of the next).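

In this assay the group on the amide-type nitrogen turns out to matter: 4-methoxyphenyl in place of cyclohexyl gives a 3.2-fold higher number from compound 2 to compound 4 (0.51 log units; beyond the scatter) and in place of 3-chlorophenyl gives a 3.2-fold higher number from compound 1 to compound 4 (0.51 log units; beyond the scatter) and so weaker inhibition. The earlier exchange at this place stayed within the scatter, so this position does respond, but not to every change. Nothing available here explains the difference. The compounds shown leave open how an unsubstituted phenyl or a 4-hydroxyphenyl would behave on this nitrogen, and so whether the methoxy group itself accounts for the step.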